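The compounds below may be only part of what the source reports. "The series", "measured", "known", "first", "only" and "open" are said of these compounds alone.

Measured so far:
- compound 1, `CC(C)[C@H](C(=O)Nc1cnns1)c1ccc(Cl)cc1`, with 57000 nM in a functional assay on CHO cells for agonist activity at Free fatty acid receptor 2 (Homo sapiens), read by cAMP accumulation; on this read-out lower numbers stand for stronger inhibition and higher numbers for weaker inhibition
- compound 2, `CC(C)[C@H](C(=O)Nc1ncc(C(F)(F)F)s1)c1ccc(Cl)cc1`, with 1500 nM in this assay
- compound 3, `CC(C)(C)[C@H](C(=O)Nc1ncc(C(F)(F)F)s1)c1ccc(Cl)cc1`, with 1500 nM in this assay

Compound 3 stands level with compound 2 at the digits shown, and the two together give the lowest numbers of the three; compound 1 lies far higher. Among the compounds with values here, the one single-point step in this set, no change at the digits printed from compound 2 to compound 3 (within the scatter), concerns the saturated chain and not the ring, so it says nothing about a change on the aromatic carbon. Compound 1 and compound 2 differ in more than one place, so their values only show that the two cores with their substituents behave very differently.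

The new compound 4, `CN(C)c1cnc(NC(=O)[C@H](c2ccc(Cl)cc2)C(C)(C)C)s1`, differs from compound 3 in one place: dimethylamino in place of trifluoromethyl on an aromatic carbon. Within the data shown here, no measured step bears on this exchange, so the expectation rests on compound 3 alone and is loose. The estimate for compound 4 is 3500 nM, with a range from 700 nM to 18000 nM, which means an expected step of a 2.3-fold higher number from compound 3 to compound 4 (0.37 log units; beyond the scatter).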

Compound 4, half-maximal inhibitory concentration: 1600 nM
For compound 4 the middle estimate is 2.2-fold (0.34 log units) above the measured one, within the range that was stated.
By their numbers in this assay, from the lowest: compounds 2, 3 and 4 (each within the scatter of the next); then compound 1.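

In this assay, the first exchange seen at this position, on an aromatic carbon next to the ring sulfur, gives a 1.1-fold higher number from compound 3 to compound 4 (0.03 log units; within the scatter), so compound 3 and compound 4 cannot be told apart. The two groups differ in what is counted on them: trifluoromethyl carries 3 fluorine and 0 hydrogen-bond acceptors, while dimethylamino carries 1 nitrogen and 1 hydrogen-bond acceptor, yet this difference does not show up in the read-out for this pair. No measurement here explains why the two groups read alike.

Going by these compounds, one pair cannot show whether this position accepts groups in general, so a carboxylic acid, a primary amine or a longer carbon chain on this carbon remains open. On these data alone, it is also open whether dimethylamino would match trifluoromethyl on the shared core with the smaller chain of compound 2.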